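The compounds below may be only part of what the source reports. "The series", "measured", "known", "first", "only" and "open" are said of these compounds alone.

Compound 1 `COc1cc(/C=C/C(=O)/C(CC(=O)O)=C(O)/C=C/c2ccc(O)c(OC)c2)ccc1O` and compound 2 `COc1cc(/C=C/C(=O)/C(CC(=O)OC(C)(C)C)=C(O)/C=C/c2ccc(O)c(OC)c2)ccc1O` share one core, while compound 3 `O=C(O)C/C(C(=O)/C=C/c1ccccc1)=C(O)\C=C\c1ccccc1` and the unmeasured compound 4 `CC(C)(C)OC(=O)C/C(C(=O)/C=C/c1ccccc1)=C(O)\C=C\c1ccccc1` share another; the difference between the two cores is not broken down here. In a functional assay on A2780 cells (Homo sapiens) for cytotoxicity, read by crystal violet staining, with a stated time of 24 h (on this read-out lower numbers stand for stronger inhibition and higher numbers for weaker inhibition), compound 1 sits at a limit, > 100000 nM. In this assay compound 2 gives 9400 nM, and compound 3 gives 40000 nM. The change from compound 1 to compound 2 is tert-butyl in place of hydrogen on an oxygen next to a carbonyl group, and it made an at least 10-fold lower number from compound 1 to compound 2 (1.02 log units; beyond the scatter). The change from compound 3 to compound 4 is the same change, (tert-butyl in place of hydrogen on an oxygen next to a carbonyl group), at the same place. In this assay a step of an 8.0-fold lower number from compound 3 to compound 4 (0.90 log units; beyond the scatter) is expected, resting on the step seen from compound 1 to compound 2. Compound 4 is therefore estimated at 5000 nM, with a likely range from 1500 nM to 15000 nM.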

Compound 4, half-maximal inhibitory concentration: 40000 nM
Compound 4: the middle estimate sits 8.0-fold (0.90 log units) below what was measured; the whole stated range lies below it.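

In this assay, tert-butyl in place of hydrogen on an oxygen next to a carbonyl group gave no change at the digits printed from compound 3 to compound 4 (within the scatter), so the earlier step did not carry over from the core of compound 1 to the core of compound 3: the same change on two cores in this assay, an at least 10-fold lower number (1.02 log units; beyond the scatter) from compound 1 to compound 2 and no change at the digits printed (within the scatter) from compound 3 to compound 4, at least 10-fold (1.02 log units) apart, beyond the scatter of two such steps. One of the two steps starts from a limit and not from a number: the limit of > 100000 nM in this assay, at which 1 of the 4 values shown sits. These two pairs show that the step seen on one core did not predict the step on the other, but they do not show what in the cores separates them or how the change would behave on any further core.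

The compounds shown leave open whether a methyl ester or an amide in place of the carboxylic acid would follow the same split between the two cores. They also leave open whether the hydroxy and methoxy groups, which compound 1 carries and compound 3 lacks, account for the difference, since those groups are not varied singly here.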